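Working notes: dioxolanyl for methoxyphenyl on the chain carbon

The compounds below may be only part of what the source reports. "The series", "measured", "known", "first", "only" and "open" are said of these compounds alone.

Measured compounds in a functional assay on B16 cells (Mus musculus) for cytotoxicity, read by MTT assay, with a stated time of 48 h; on this read-out higher numbers stand for weaker inhibition and lower numbers for stronger inhibition:
Compound 1 `CCOC(=O)Cn1cc(-c2ccc(OC)c(OC)c2OC)nn1` gives > 100000 nM, a limit of the assay.
Compound 2 `Cc1cccc(-c2cn(C[C@H]3COC(C)(C)O3)nn2)c1` gives > 100000 nM, a limit of the assay.
Compound 3 `COc1cccc(Cn2cc(-c3ccc(OC)c(OC)c3OC)nn2)c1` gives > 100000 nM, a limit of the assay.

Compound 3 thus stands at the limit, as do the other two, and nothing separates them (the limit of > 100000 nM in this assay, at which 3 of the 3 values shown sit). Going by the values given here, the only measured step, a step that the two limits leave unreadable from compound 1 to compound 3, runs between two limits and is unreadable. Compound 4 `COc1ccc(-c2cn(C[C@H]3COC(C)(C)O3)nn2)c(OC)c1OC` differs from compound 3 by 2,2-dimethyl-1,3-dioxolan-4-yl in place of 3-methoxyphenyl on a saturated chain carbon bound to an aromatic nitrogen. Among the compounds with values here, no measured step bears on this change. Compound 2, which carries the same 2,2-dimethyl-1,3-dioxolan-4-yl group on a saturated chain carbon bound to an aromatic nitrogen, also sits at a limit in this assay. The step that the limit leaves unreadable from compound 3 to compound 4 is therefore expected to be none beyond the scatter. Compound 4 is expected to give 150000 nM, within a range from 30000 nM to 1000000 nM, most likely reported again only as a limit.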

Compound 4, half-maximal inhibitory concentration: > 100000 nM
Compound 4: a limit, no number (the forecaster's own chance of this, stated with the estimate: 80%); the middle value lies beyond the limit too.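

No new step can be read: those from compound 3 and from compound 1 to compound 4 each join two limits of the assay: the limit of > 100000 nM in this assay, at which 4 of the 4 values shown sit. The compounds shown leave open whether any change on the chain carbon affects cytotoxicity.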